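A few compounds are considered here, and "the series" means these few. Any claim that something is new, unique, unknown or untested is made for them only; others in the source may bear on it.

- compound 1 `O=C(Cc1csc2nc(-c3ccc(Br)cc3)cn12)N/N=C/c1ccccc1`: 37200 nM
- compound 2 `COc1cccc(OC)c1/C=N/NC(=O)Cc1csc2nc(-c3ccc(Br)cc3)cn12`: 35500 nM
- compound 3 `O=C(Cc1csc2nc(-c3ccc(Br)cc3)cn12)N/N=C/c1ccc(Cl)cc1Cl`: not yet measured

In a functional assay on HOP-92 cells (Homo sapiens) for inhibition, read by sulforhodamine B assay, with a stated time of 48 h (a lower number here means a stronger inhibitor of growth, a higher number a weaker inhibitor of growth), compound 2 sits within the scatter of compound 1, so the two values show no order. The next change, to compound 3, is 2,4-dichlorophenyl in place of 2,6-dimethoxyphenyl on a carbon with a double bond to nitrogen. Among the measured compounds shown here, one measured step bears on it, at the same place: a 1.0-fold lower number from compound 1 to compound 2 (0.02 log units; within the scatter). For the measured compounds named here, that step stays within the scatter, but no measured compound yet carries 2,4-dichlorophenyl, so this support is thin. No change beyond the scatter is expected, and the estimate is a 1.1-fold lower number from compound 2 to compound 3 (0.05 log units; within the scatter). Compound 3 is estimated at 32000 nM, with an expected range of 14000 nM to 70000 nM.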

Compound 3, concentration for total growth inhibition: > 100000 nM
Compound 3: only a limit was reported; the forecaster's own chance of this, stated with the estimate: 10%; middle value at least 3.1-fold (0.49 log units) away from the limit.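

At the position on a carbon with a double bond to nitrogen, the aryl group now separates the compounds in this assay: 2,4-dichlorophenyl gives an at least 2.8-fold higher number from compound 2 to compound 3 (0.44 log units; beyond the scatter) and, against phenyl, an at least 2.6-fold higher number from compound 1 to compound 3 (0.42 log units; beyond the scatter). Phenyl and 2,6-dimethoxyphenyl had shown no separation here, so this place is not indifferent to the group it carries. The result for compound 3 is a limit, not a number: the limit of > 100000 nM in this assay, at which 1 of the 3 values shown sits.

Going by these compounds, the true size of both steps remains open. Also open, on these data alone, is whether an amine or a carboxylic acid on this phenyl would leave the number close to that of compound 1 or move it.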